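Benzyloxy aryl acylurea series: notes toward compound 4

The source may hold more compounds than are shown below. What is called first, only, known or untested is meant among the compounds shown, and "the series" means these compounds.

Compound 1 `Cc1ccc(NC(=S)NC(=O)c2ccc(OCc3ccccc3F)cc2)cc1-c1nc2ccccc2[nH]1` gives 3070 nM in a functional assay on MGC-803 cells (Homo sapiens) for inhibition, read by MTT assay, with a stated time of 48 h; a lower number here means a stronger inhibitor, a higher number a weaker inhibitor. Compound 2 `Cc1ccc(COc2ccc(C(=O)NC(=S)Nc3ccc(C)c(-c4nc5ccccc5[nH]4)c3)cc2)cc1` gives 4980 nM in this assay; the change 4-methylphenyl in place of 2-fluorophenyl on a saturated chain carbon bound to an oxygen on an aromatic ring made a 1.6-fold higher number from compound 1 to compound 2 (0.21 log units; within the scatter). Compound 3 `O=C(NC(=O)c1ccc(OCc2ccccc2F)cc1)Nc1ccc(Cl)c(-c2nc3ccccc3[nH]2)c1` gives 120 nM in this assay, the lowest number of the three, well clear of the other two. The difference between the core of compound 3 and the core of compound 1 is not broken down here. Compound 4 `Cc1ccc(COc2ccc(C(=O)NC(=O)Nc3ccc(Cl)c(-c4nc5ccccc5[nH]4)c3)cc2)cc1` has not been measured; it carries the same change 4-methylphenyl in place of 2-fluorophenyl on a saturated chain carbon bound to an oxygen on an aromatic ring on the core of compound 3. In this assay, among the measured compounds shown here, the expected step is a 1.5-fold higher number from compound 3 to compound 4 (0.18 log units; within the scatter), set beside the measured 1.6-fold higher number from compound 1 to compound 2 (0.21 log units; within the scatter), which is the single instance of this change and the only guide to it. For compound 4 the estimate in this assay is 180 nM, expected to fall between 80 nM and 450 nM.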

Compound 4, half-maximal inhibitory concentration: 3860 nM
Compound 4: middle estimate off by 21-fold (1.33 log units), on the low side, outside the stated range (above it).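

In this assay, 4-methylphenyl in place of 2-fluorophenyl gives a 32-fold higher number from compound 3 to compound 4 (1.51 log units; beyond the scatter), so the step does not carry over at the same size from one core to the other: the same change on two cores in this assay, a 1.6-fold higher number (0.21 log units; within the scatter) from compound 1 to compound 2 and a 32-fold higher number (1.51 log units; beyond the scatter) from compound 3 to compound 4, 20-fold (1.30 log units) apart, beyond the scatter of two such steps

The step measured on the core of compound 1 is therefore a poor guide to the same change on the core of compound 3. The two cores differ in more than one place, and these two pairs do not show which difference matters, nor do they give a rule for any other core.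

Still open, as far as these compounds go, is how the core of compound 3 responds to other groups at this place, such as an amine or a carboxylic acid. Also open, from the compounds shown here alone, is whether the large step tracks the arrival of 4-methylphenyl or the departure of 2-fluorophenyl.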